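A few compounds are considered here, and "the series" means these few. Any claim that something is new, unique, unknown or untested is made for them only; others in the source may bear on it.

Measured in a functional assay on HeLa cells (Homo sapiens) for inhibition, read by MTT assay, with a stated time of 48 h; a higher number here means a weaker inhibitor, a lower number a stronger inhibitor:
- Compound 1 `Cc1ccc(/C=C2\SC(=O)N(CC(=O)Nc3c(C)n(C)n(-c4ccccc4)c3=O)C2=O)cc1`: 53100 nM
- Compound 2 `COc1ccc(/C=C2\SC(=O)N(CC(=O)Nc3c(C)n(C)n(-c4ccccc4)c3=O)C2=O)cc1`: 64800 nM

For the measured compounds named here, compound 2 stands level with compound 1, the only other compound measured. The two cannot be told apart, as the comparison gives a 1.2-fold higher number from compound 1 to compound 2 (0.09 log units; within the scatter).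

Compound 3 `Cc1c(NC(=O)CN2C(=O)S/C(=C\c3ccc([N+](=O)[O-])cc3)C2=O)c(=O)n(-c2ccccc2)n1C` keeps the shared core and alters one group, with nitro in place of methoxy on an aromatic carbon. Put another way, 4-methoxyphenyl becomes 4-nitrophenyl.

Going by the values given here, only one measured change bears on this, methoxy in place of methyl on an aromatic carbon, and its size was small: a 1.2-fold higher number from compound 1 to compound 2 (0.09 log units; within the scatter). Among the compounds with values here, no measured compound carries a nitro group, so this single step is a thin guide and the uncertainty remains wide. On this evidence, no shift beyond the scatter is expected in either direction. The estimated change is a 1.2-fold lower number from compound 2 to compound 3 (0.07 log units; within the scatter). For compound 3 the expected value is 55000 nM, with an estimated range from 22000 nM to 120000 nM.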

Compound 3, half-maximal inhibitory concentration: 77200 nM
Beside the measured number, compound 3's estimate is 1.4-fold (0.15 log units) below it, and the stated range covers the measured number.
By their numbers in this assay, from the lowest: compounds 1, 2 and 3 (each within the scatter of the next).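

In this assay, the nitro group brings a nitrogen-bearing group of three heavy atoms to the position on the aromatic carbon para to a large group, yet the exchange for methoxy stays within the scatter (a 1.2-fold higher number from compound 2 to compound 3 (0.08 log units; within the scatter)). The exchange of methyl for nitro at the same carbon also stays within the scatter (a 1.5-fold higher number from compound 1 to compound 3 (0.16 log units; within the scatter)), so the methyl, methoxy and nitro compounds cannot be told apart, which extends the earlier result for methyl and methoxy alone to a third, quite different group. No evidence is available that would explain why these three exchanges leave the number within the scatter.

The compounds shown leave open whether any group at this position can move the number beyond the scatter, as an amine, a carboxylic acid or a longer chain there might. They also leave open whether changes elsewhere on the shared core, such as replacing its unsubstituted phenyl group with a 4-chlorophenyl group, would matter more than the three exchanges seen at this carbon.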